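Notes on compound 4, estimated from compound 3

The source may hold more compounds than are shown below. What is called first, only, known or untested is meant among the compounds shown, and "the series" means these compounds.

Compound 1 `C[C@H](Nc1nc(N)nc(N)c1C#N)c1cc(=O)n2cc(F)ccc2c1-c1ccccc1`: "not determined" (no result reported) in an ADME assay on microsomes from liver (Rattus norvegicus), read by LC-MS, using NADPH, with a stated time of 30 min, tested at 1 uM; on this read-out higher numbers stand for a more stable compound and lower numbers for a less stable compound
Compound 2 `C[C@H](Nc1nc(N)nc(N)c1C#N)c1cc(=O)n2cc(F)ccc2c1-c1ccc(F)cc1`: "not determined" (no result reported) in this assay
Compound 3 `C[C@H](Nc1ncnc(N)c1C#N)c1cc(=O)n2cc(F)ccc2c1-c1cc(F)cc(F)c1`: 60% in this assay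

Among the compounds with values here, compound 3 carries the only number so far; the other two measured entries report nothing, so no step between measured compounds can be drawn in this assay. Compound 4 `C[C@H](Nc1nc(N)nc(N)c1C#N)c1cc(=O)n2cc(F)ccc2c1-c1cc(F)cc(F)c1` differs from compound 3 by amino in place of hydrogen on an aromatic carbon. Without any comparable step in the series, no direction can be supported; the expected change is none beyond the usual scatter, with a wide band. Compound 4 is therefore estimated at 62%, in the range 40% to 85%, an expected step of a number 2 percentage points higher from compound 3 to compound 4 (within the scatter).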

Compound 4, percent of the compound remaining: 87%
Beside the measured number, compound 4's estimate is 25 percentage points below it, and the stated range ends below it.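

In this assay, within the data shown here, amino in place of hydrogen on an aromatic carbon, between two ring nitrogen atoms, gives a number 27 percentage points higher from compound 3 to compound 4 (beyond the scatter) as the first readable step, so this position responds to the change. Compound 1 and compound 2 report no result, so their comparisons with compound 4 cannot be read. No measurement shown bears on the origin of this step.

Going by these compounds, whether a methyl or a dimethylamino group on this carbon would give a similar read-out stays open. So does whether the step holds with other aromatic groups on the shared core.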